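Compound 4 and the limit of the cytotoxicity read-out

A few compounds are considered here, and "the series" means these few. Any claim that something is new, unique, unknown or untested is made for them only; others in the source may bear on it.

Values in an ADME assay on HepG2 cells (Homo sapiens) for cytotoxicity, in the presence of a further agent that is not named here (on this read-out higher numbers stand for weaker inhibition and lower numbers for stronger inhibition), for the measured compounds, each one a limit and not a number
- Compound 1 `Cn1c(Cc2ccccc2)nc(C(=O)NCc2ccccc2)c(O)c1=O` gives > 100000 nM as a limit
- Compound 2 `Cn1c(Cc2ccccc2C(F)(F)F)nc(C(=O)Nc2ccccc2)c(O)c1=O` gives > 100000 nM as a limit
- Compound 3 `Cn1c(Cc2ccccc2C(F)(F)F)nc(C(=O)CCc2ccccc2)c(O)c1=O` gives > 100000 nM as a limit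

Compound 3 has no number in this assay and stands only at > 100000 nM as a limit. Across the series the data show the limit of > 100000 nM in this assay, at which 3 of the 3 values shown sit, and no compound yet gives a number.

Compound 4 `Cn1c(Cc2ccccc2C(F)(F)F)nc(C(=O)NCc2ccccc2)c(O)c1=O` follows from compound 3 by benzylamino in place of phenethyl on a carbonyl carbon and thus has benzylamino in place of phenethyl on a carbonyl carbon. Within the data shown here, the only measured step is a step that the two limits leave unreadable from compound 2 to compound 3 and so it offers no size to carry over. Compound 1 also carries the benzylamino group, without the trifluoromethyl, and gives > 100000 nM as a limit. On this basis, no change beyond the scatter is expected in either direction. The estimated step is a step that the limit leaves unreadable from compound 3 to compound 4 and compound 4 will most likely be reported as a limit again. Compound 4 is expected at 120000 nM within an estimated range of 60000 nM to 300000 nM in this read-out.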

Compound 4, half-maximal inhibitory concentration: > 100000 nM
Compound 4: only a limit was reported; the forecaster's own chance of this, stated with the estimate: 90%; the middle value does not contradict the limit.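

Compound 4 again gives only a limit and not a number in this assay, so the steps to it from compound 1, compound 2 and compound 3 cannot be read: the limit of > 100000 nM in this assay, at which 4 of the 4 values shown sit.

The compounds shown leave open whether any of these changes alters the result in this assay at all.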